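The compounds below may be only part of what the source reports. "The series", "measured", "known", "first", "only" and "open" are said of these compounds alone.

Measured in a functional assay on HCT-116 cells (Homo sapiens) for inhibition, read by MTT assay, with a stated time of 72 h; a lower number here means a stronger inhibitor, a higher number a weaker inhibitor:
- compound 1 `CC1=NN(c2ccccc2)C(=O)[C@@]12C(=O)C=CC[C@@H]2c1ccccc1[N+](=O)[O-]`: 66800 nM
- compound 2 `CC1=NN(c2ccccc2)C(=O)[C@@]12C(=O)C=CC[C@H]2c1ccc(C)cc1`: 5210 nM

Of these two, compound 2 has the lower number, 5210 nM, and the gap to compound 1 lies beyond the usual scatter. Compound 3 `CC1=NN(c2ccccc2)C(=O)[C@@]12C(=O)C=CC[C@@H]2c1ccc(C)cc1` keeps every atom and bond of compound 2: the two compounds have the same atoms and bonds and differ only in configuration as drawn: 1 of 2 stereo elements differ; a stereocentre at a saturated ring carbon is drawn S in compound 2 and R in compound 3. Within the data shown here, no measured pair here isolates such a change, so any expectation is loose. Among the measured compounds shown here, compound 2, at 5210 nM, is the lower of only two numbers, so a modest rise in this assay seems likelier than a further fall. The expected change is a 1.7-fold higher number from compound 2 to compound 3 (0.24 log units; within the scatter). For compound 3 the estimate is 9000 nM, with an expected range of 2500 nM to 35000 nM.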

Compound 3, half-maximal inhibitory concentration: 5220 nM
For compound 3 the middle estimate is 1.7-fold (0.24 log units) above the measured one; the measured number falls inside the stated range.
By their numbers in this assay, from the lowest: compounds 2 and 3 (each within the scatter of the next); then compound 1.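

In this assay, the step at this saturated ring carbon is a 1.0-fold higher number from compound 2 to compound 3 (0.00 log units; within the scatter), so the drawn configuration there makes no difference beyond the scatter. This pair isolates that single change: the fact that compounds 2 and 3 differ only in the configuration as drawn. With the configuration held, 4-methylphenyl in place of 2-nitrophenyl gives a 13-fold lower number from compound 1 to compound 3 (1.11 log units; beyond the scatter), so the earlier gap can now be tied to the group alone.

From the compounds shown here alone, it remains open whether configuration at this carbon would matter equally little with 2-nitrophenyl there. Also open, going by these compounds, is how a phenyl ring carrying an amine or a carboxylic acid would behave at this place.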